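Methoxy on the anilino ring of a thiazole amide

The source may report more compounds than this note shows. Statements on the series, on what has been measured and on what is new or still open speak of the compounds shown alone.

Measured compounds:
compound 1, `Cc1nc(SCC(=O)Nc2nc(-c3ccc(Cl)cc3)cs2)n(Nc2ccccc2)c1C`, 10800 nM
compound 2, `Cc1ccc(Nn2c(SCC(=O)Nc3nc(-c4ccccc4)cs3)nc(C)c2C)cc1`, 2480 nM

Both compounds share a core in which a thioether-linked acetamide joins a substituted thiazole to an anilino-bearing heterocycle. In a functional assay on Malme-3M cells (Homo sapiens) for antiproliferative activity, read by sulforhodamine B assay, with a stated time of 48 h (a lower number here means a stronger inhibitor of growth, a higher number a weaker inhibitor of growth), compound 1 gives 10800 nM, the highest number of the two, which here means the weaker inhibitor of growth. Compound 2 gives 2480 nM in this assay, a lower number well beyond the usual scatter; compound 2 differs from compound 1 in more than one place, so the two values alone cannot be traced to a single change.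

The new compound is compound 3, `COc1ccc(Nn2c(SCC(=O)Nc3nc(-c4ccc(Cl)cc4)cs3)nc(C)c2C)cc1`. Relative to compound 1 the change is methoxy in place of hydrogen on an aromatic carbon, with everything else unchanged. Among the compounds with values here, no measured pair isolates this change, so the expected size of the step in this assay rests only on the two values known. A moderate move toward a lower number seems plausible, but a step within the scatter cannot be excluded. Compound 3 is estimated at 5000 nM, with a range of 1500 nM to 16000 nM, which amounts to an expected step of a 2.2-fold lower number from compound 1 to compound 3 (0.33 log units; beyond the scatter).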

Compound 3, concentration for 50% growth inhibition: 2900 nM
Compound 3: middle estimate off by 1.7-fold (0.24 log units), on the high side; the measured number falls inside the stated range.
By their numbers in this assay, from the lowest: compounds 2 and 3 (each within the scatter of the next); then compound 1.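

Within the data shown here, compound 1 and compound 3 differ in one place only, so this is the first pair in which a change in activity can be followed to a single spot: the ring carbon of the anilino group that lies para to a large group. In this assay, putting methoxy in place of hydrogen there gives a 3.7-fold lower number from compound 1 to compound 3 (0.57 log units; beyond the scatter), showing that this position responds to substitution and that methoxy, far from costing activity, goes with stronger inhibition of growth in this pair. Nothing measured here accounts for the size or direction of this step.

From the compounds shown here alone, it remains open whether this gain is particular to methoxy or would also come with another group at the same carbon, such as a hydroxyl, an amine or a longer chain like ethoxy. Going by these compounds, it is equally open whether methoxy would give a similar step on a compound lacking the chlorine of compound 1, since a single pair cannot show how far the effect carries over to other parts of the series.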